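This account rests on a few compounds, and the source may have more. Where it says the series, first, only, none or still open, it means among the compounds named here.

Within the data shown here, compound 1, `CC#CC(CC(=O)O)c1ccc(OCc2ccn3cc(-c4ccccc4)nc3c2)cc1`, is one of two compounds measured in an assay on isolated protein for agonist activity at Free fatty acid receptor 1 (Homo sapiens); on this read-out higher numbers stand for an effect only at larger amounts of compound and lower numbers for an effect already at smaller amounts. In this assay compound 1 gives 1260 nM, the highest of the two numbers. The other compound, compound 2 with structure `CC#CC(CC(=O)O)c1ccc(OCc2ccc3nc(-c4ccccc4C)cn3c2)cc1`, carries a different arrangement of the shared core and a methyl-bearing phenyl; in this assay compound 2 gives 389 nM, a lower number than compound 1, and the two values lie beyond the usual scatter. Among the measured compounds shown here, no single-point step between them is available, so the account can only say what the two values show.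

Compound 3, `CC#CC(CC(=O)O)c1ccc(OCc2ccn3cc(-c4ccc(CC)cc4)nc3c2)cc1`, is not yet measured. It differs from compound 1 in one place: ethyl in place of hydrogen on an aromatic carbon, which, cut one bond further out, reads phenyl to 4-ethylphenyl. For the measured compounds named here, with no measured pair of this kind to lean on, the expectation rests only on the values of compound 1 and compound 2. Compound 3 is expected to give a somewhat lower number than compound 1, a modest step of a 2.1-fold lower number from compound 1 to compound 3 (0.32 log units; beyond the scatter), though a result within the scatter would not surprise. The estimate for compound 3 in this assay is 600 nM, within a range from 200 nM to 2000 nM.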

Compound 3, half-maximal effective concentration: 671 nM
Compound 3: the middle estimate sits 1.1-fold (0.05 log units) below what was measured; the range from low to high includes it.
By their numbers in this assay, from the lowest: compounds 2, 3 and 1 (each within the scatter of the next, the first and the last beyond it).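

In this assay, ethyl in place of hydrogen on an aromatic carbon of the phenyl, para to a large group, gives a 1.9-fold lower number from compound 1 to compound 3 (0.27 log units; within the scatter), so the change cannot be told apart from repeated measurement of a single compound. Among these compounds, this is the first single-place step: the two earlier compounds differ in more than one place and could say nothing about this position alone. It shows that, in the setting of compound 1, this position accepts an ethyl group with no change in the read-out beyond the scatter, though this rests on one pair, and nothing shown here offers an explanation for the result.

What the compounds shown leave open is whether this tolerance extends to other groups at the same position, such as a methoxy group, an amine, a carboxylic acid or a longer chain like hexyl, any of which might move the number beyond the scatter in either direction. As far as these compounds go, it also remains open whether ethyl would behave the same way on the methyl-bearing phenyl of compound 2.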